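The source may hold more compounds than are shown below. What is called first, only, known or untested is meant among the compounds shown, and "the series" means these compounds.

Working notes on the para-substituted dienamide series. The shared core, with a piperidine amide on the diene, carries a chloro in compound 3 → no: compound 1 `O=C(/C=C/C=C/c1ccc(Cl)cc1)N1CCCCC1` carries chloro, compound 2 `O=C(/C=C/C=C/c1ccc(O)cc1)N1CCCCC1` hydroxy, compound 3 `O=C(/C=C/C=C/c1ccc(F)cc1)N1CCCCC1` fluoro. In an assay for inhibition of Polyunsaturated fatty acid 5-lipoxygenase (Homo sapiens), read by spectrophotometry, tested at 20 uM (on this read-out higher numbers stand for more inhibition at the one concentration tested (going by the name of the read-out) and lower numbers for less inhibition), compound 1 gives 14.5%, compound 2 gives 44.4% and compound 3 gives 48.7%. Compound 3 lies beyond the scatter above compound 1, seen in a number 34.2 percentage points higher from compound 1 to compound 3 (beyond the scatter), but within the scatter of compound 2, seen in a number 4.3 percentage points higher from compound 2 to compound 3 (within the scatter); likewise a number 29.9 percentage points higher from compound 1 to compound 2 (beyond the scatter).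

Compound 4 `COc1ccc(/C=C/C=C/C(=O)N2CCCCC2)cc1` differs from compound 3 by methoxy in place of fluoro on an aromatic carbon. Among the compounds with values here, no measured step involves methoxy; the hydroxy-to-fluoro comparison lies within the scatter, while only chloro sits clearly lower. The number for compound 4 in this assay is therefore expected near that of compound 3 or somewhat lower, a step of a number 10.7 percentage points lower from compound 3 to compound 4 (beyond the scatter). Estimated value for compound 4: 38%, range 15% to 60%.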

Compound 4, a percentage reported as inhibition, at one concentration (the size of the read-out at that concentration, not a potency): 42.6%
Beside the measured number, compound 4's estimate is 4.6 percentage points below it; measured number inside the range.
By their numbers in this assay, from the lowest: compound 1; then compounds 4, 2 and 3 (each within the scatter of the next).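

At this position, para to a large group, methoxy adds a third group that cannot be told apart from fluoro and hydroxy in this assay, with a number 6.1 percentage points lower from compound 3 to compound 4 (within the scatter) and a number 1.8 percentage points lower from compound 2 to compound 4 (within the scatter); methyl in place of hydrogen on the oxygen therefore leaves no readable change. Chloro remains the one group apart, with a number 28.1 percentage points higher from compound 1 to compound 4 (beyond the scatter). No evidence bears on why these groups read as they do. Still open, on these data alone, is how an amine or a carboxylic acid would read at this position. As far as these compounds go, a longer chain on the oxygen, such as ethoxy, also remains open.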